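Growth inhibition notes: the step to compound 4

The compounds below may be only part of what the source reports. "The series", "measured", "known", "first", "only" and "open" are said of these compounds alone.

Measured so far in a functional assay on HCC 2998 cells (Homo sapiens) for inhibition, read by sulforhodamine B assay, with a stated time of 48 h; a higher number here means a weaker inhibitor of growth, a lower number a stronger inhibitor of growth
- compound 1 `O=C(Cc1csc2nc(-c3ccc(Br)cc3)cn12)N/N=C/c1ccccc1` gives 13200 nM
- compound 2 `O=C(Cc1csc2nc(-c3ccc(Br)cc3)cn12)N/N=C/c1ccccc1O` gives 3470 nM
- compound 3 `O=C(Cc1csc2nc(-c3ccc(Br)cc3)cn12)N/N=C/c1ccc(O)cc1` gives 14500 nM

Compound 3 cannot be told apart from compound 1 on these numbers, with a 1.1-fold higher number from compound 1 to compound 3 (0.04 log units; within the scatter) as the only difference. It stands clearly apart from compound 2, with a 4.2-fold higher number from compound 2 to compound 3 (0.62 log units; beyond the scatter) on record. Next comes compound 4 `O=C(Cc1csc2nc(-c3ccc(Br)cc3)cn12)N/N=C/c1ccc(Cl)cc1Cl` with 2,4-dichlorophenyl in place of 4-hydroxyphenyl on a carbon with a double bond to nitrogen as the counted change.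

Among the compounds with values here, two measured steps bear on this. Removing the hydroxy of compound 3 would undo a 1.1-fold higher number from compound 1 to compound 3 (0.04 log units; within the scatter) in the series, so that loss alone should move the number little. Within the data shown here, compound 2 is the only compound that departs from the others, through a 3.8-fold lower number from compound 1 to compound 2 (0.58 log units; beyond the scatter) as the single clear gain, but it carries hydroxy and not chlorine. Among the measured compounds shown here, no measured compound carries chlorine, so the size of the change is poorly fixed. A small step toward a lower number in this assay is expected, no larger than the modest steps seen so far. The estimated step is a 1.8-fold lower number from compound 3 to compound 4 (0.26 log units; within the scatter) as the working expectation. For compound 4 the expected value is 8000 nM with an estimated range from 2500 nM to 20000 nM in this series.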

Compound 4, concentration for 50% growth inhibition: 20000 nM
The estimate for compound 4 lay 2.5-fold (0.40 log units) below the measured number, and the stated range covers the measured number.
By their numbers in this assay, from the lowest: compound 2; then compounds 1, 3 and 4 (each within the scatter of the next).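

In this assay, putting 2,4-dichlorophenyl on the carbon with a double bond to nitrogen gives a 1.4-fold higher number from compound 3 to compound 4 (0.14 log units; within the scatter) and a 1.5-fold higher number from compound 1 to compound 4 (0.18 log units; within the scatter), so compound 4 cannot be told apart from compound 1 or compound 3 even though the entering group has two chlorines and no hydrogen-bond donor or acceptor. The chlorine-bearing ring does not reproduce the result of 2-hydroxyphenyl, with a 5.8-fold higher number from compound 2 to compound 4 (0.76 log units; beyond the scatter), and among these four compounds the single clear departure remains compound 2. No available evidence bears on the reason for this pattern.

The compounds shown leave open whether the lower number of compound 2 depends on the hydroxy itself, a question that a 2-methoxyphenyl, 2-aminophenyl or 2-chlorophenyl group on this carbon would help to settle. They also leave open whether a single chlorine, as in 4-chlorophenyl, would read the same as 2,4-dichlorophenyl, and whether a 2,4-dihydroxyphenyl group would keep or lose the gain seen with compound 2.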